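A few compounds are considered here, and "the series" means these few. Any claim that something is new, unique, unknown or untested is made for them only; others in the source may bear on it.

Measured so far in an ADME assay on Vero cells (Chlorocebus sabaeus) for cytotoxicity, read by reporter gene assay, with a stated time of 4 days; a lower number here means a stronger inhibitor, a higher number a weaker inhibitor:
- compound 1 `CCCCCC(=O)NCC(C)(C)CC1=C(O)C(=O)c2ccccc2C1=O`: 46600 nM
- compound 2 `CCCCCCC(=O)NCC(C)(C)CC1=C(O)C(=O)c2ccccc2C1=O`: 24800 nM

Only these two compounds have been measured, and compound 2, at 24800 nM, cannot be separated from compound 1. For the measured compounds named here, the one measured step is a 1.9-fold lower number from compound 1 to compound 2 (0.27 log units; within the scatter), so the two stand level within the scatter.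

The next compound, compound 3 `CCCCCCCC(=O)NCC(C)(C)CC1=C(O)C(=O)c2ccccc2C1=O`, differs from compound 2 by methyl in place of hydrogen on a saturated chain carbon, six bonds along the chain from a carbonyl carbon. This is methyl in place of hydrogen on a saturated chain carbon, six bonds along the chain from a carbonyl carbon. Going by the values given here, the measured step made the same kind of change five bonds along the chain from a carbonyl carbon, which makes it the only direct guide.

That single step did not clear the scatter, and one step does not establish a trend. A small move towards a lower number in this assay is therefore expected, of about the same size as the earlier step, and it may well not exceed the scatter. The expected step is a 1.6-fold lower number from compound 2 to compound 3 (0.19 log units; within the scatter). For compound 3 the estimated value is 16000 nM, with an expected range from 7000 nM to 35000 nM.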

Compound 3, half-maximal inhibitory concentration: 18400 nM
The estimate for compound 3 lay 1.2-fold (0.06 log units) below the measured number, within the range that was stated.
By their numbers in this assay, from the lowest: compounds 3, 2 and 1 (each within the scatter of the next, the first and the last beyond it).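

Methyl in place of hydrogen on a saturated chain carbon, six bonds along the chain from a carbonyl carbon, gives a 1.3-fold lower number from compound 2 to compound 3 (0.13 log units; within the scatter) in this assay, so this change alone, like the one before it, cannot be told apart from repeat measurement. Read across both changes, the result is a 2.5-fold lower number from compound 1 to compound 3 (0.40 log units; beyond the scatter) and is the first step here to clear the scatter, though only modestly, while compound 2 stays within the scatter of both the others. Nothing measured here bears on the reason for this difference.

The compounds shown cannot say whether a longer chain would carry the number further in the same direction, hold it level or turn it back. They also leave open how a phenyl ring, an amine or a carboxylic acid on this chain would read in this assay when set against the simple chains compared so far.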